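The compounds below may be only part of what the source reports. "The series", "measured", "known", "first", "only" and "open" are said of these compounds alone.

In an ADME assay on BJ cells (Homo sapiens) for cytotoxicity, with a stated time of 72 h (on this read-out higher numbers stand for an effect only at larger amounts of compound and lower numbers for an effect already at smaller amounts), compound 1 `O=C(O)COc1cc(Cl)c(C(=O)Nc2cccc(-c3nc4ccccc4s3)c2)cc1[N+](=O)[O-]` is recorded at > 25000 nM, which is a limit. Compound 2 `O=C(Nc1nc2c(Cl)cccc2s1)c1cc([N+](=O)[O-])ccc1Cl` is recorded at > 27000 nM, also a limit. Among the compounds with values here, compound 3 `O=C(Nc1nc(-c2ccc(Cl)cc2)cs1)c1cc([N+](=O)[O-])ccc1Cl` gives 18000 nM, the only actual number among the three. Compound 4 `O=C(Nc1nc(-c2ccc(F)c(F)c2)cs1)c1cc([N+](=O)[O-])ccc1Cl` differs from compound 3 in one place, with 3,4-difluorophenyl in place of 4-chlorophenyl on an aromatic carbon. Within the data shown here, no measured pair of compounds shows the size of such a change in this assay. A step within the usual scatter is therefore expected, with no firm direction. The estimated step is a 1.1-fold higher number from compound 3 to compound 4 (0.05 log units; within the scatter). For compound 4 the expected value is 20000 nM, with an estimated range from 9000 nM to 35000 nM.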

Compound 4, half-maximal effective concentration: > 27000 nM
Compound 4 ended at the assay's limit (the forecaster's own chance of this, stated with the estimate: 35%); middle value at least 1.3-fold (0.13 log units) away from the limit.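

With 3,4-difluorophenyl in place of 4-chlorophenyl, this position on the ring gives its first readable step in this assay, namely an at least 1.5-fold higher number from compound 3 to compound 4 (0.17 log units; that floor lies within the scatter) (a floor only). The value of compound 4 is a limit, the same one printed for compound 2: the limit of > 27000 nM in this assay, at which 2 of the 4 values shown sit. Going by these compounds, the change therefore shows no firm direction, and its true size stays unknown.

What the compounds shown leave open is how an amine or a carboxylic acid on this phenyl ring would read out. Also open, on these data alone, is whether a single fluorine would differ from these two groups.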